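The source may report more compounds than this note shows. Statements on the series, on what has been measured and on what is new or still open speak of the compounds shown alone.

Compound 2 `O=C(O)c1cnc2c(C(F)(F)F)cccc2c1` and compound 1 `FC(F)(F)c1cccc2cc(-c3nn[nH]n3)cnc12` share one core and differ in a single place, (2H-tetrazol-5-yl in place of carboxy on an aromatic carbon). In a functional assay on the whole organism (strain Sprague-Dawley) for inhibition, with Rattus norvegicus as the target (a lower number here means that less compound is needed, a higher number that more compound is needed for the effect), compound 2 gives 50 mg/kg. Compound 1 reaches a limit of this assay, < 25 mg/kg. The step of an at least 2.0-fold lower number from compound 2 to compound 1 (0.30 log units; that floor lies within the scatter) therefore rests on the limit of < 25 mg/kg in this assay, at which 1 of the 3 values shown sits, rather than on a full number. Compound 3 `Cc1ccc2cc(C(=O)O)cnc2c1C` carries another core; how that core differs from the core of compound 2 is not broken down here. In this assay compound 3 gives 25 mg/kg. Compound 4 `Cc1ccc2cc(-c3nn[nH]n3)cnc2c1C` is not yet measured; it differs from compound 3 by 2H-tetrazol-5-yl in place of carboxy on an aromatic carbon, the same change as before, at the same place. The expected step is a 2.0-fold lower number from compound 3 to compound 4 (0.30 log units; within the scatter), set beside the earlier at least 2.0-fold lower number from compound 2 to compound 1 (0.30 log units; that floor lies within the scatter) from which it is taken. The expected value for compound 4 is 12.5 mg/kg, lying between 6 mg/kg and 30 mg/kg.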

Compound 4, minimum effective dose: 1 mg/kg
Compound 4: middle estimate off by 13-fold (1.10 log units), on the high side; the whole stated range lies above it.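

In this assay, putting 2H-tetrazol-5-yl in place of carboxy gives a 25-fold lower number from compound 3 to compound 4 (1.40 log units; beyond the scatter), so on this core the change pays off clearly. The same change on the other core points the same way, but this does not show that the size of the gain carries over from one core to the other: the same change on two cores in this assay, an at least 2.0-fold lower number (0.30 log units; that floor lies within the scatter) from compound 2 to compound 1 and a 25-fold lower number (1.40 log units; beyond the scatter) from compound 3 to compound 4; the limit leaves it open whether they differ The value of compound 1, < 25 mg/kg, is a limit and not a number, so that earlier step gives only a floor: the limit of < 25 mg/kg in this assay, at which 1 of the 4 values shown sits.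

For the compounds shown here, only two cores and one replacement appear here, so it stays open whether the gain would hold on a core bearing an amine or a longer chain. On these data alone, how an amide would fare in place of the carboxy also remains open.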